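The source may report more compounds than this note shows. Statements on the series, on what has been measured and on what is new or still open speak of the compounds shown alone.

In a functional assay on the whole organism (strain Kunming) with Mus musculus as the target, with a stated time of 0.5 h (a lower number here means that less compound is needed, a higher number that more compound is needed for the effect), three esters built on one shared core have been tested so far. Compound 1 (`COc1cc(OC)c(OC)cc1/C=C/COC(=O)/C=C/c1cc(OC)c(OC)c(OC)c1OC`) gives > 200 mg/kg as a limit of the assay and not a number. Compound 3 (`COc1cc(OC)c(OC)cc1/C=C/COC(=O)/C=C/c1cc(OC)c(OC)c(OC)c1`) gives > 200 mg/kg as a limit as well. Compound 2 (`COc1cc(OC)c(OC)cc1/C=C/COC(=O)/C=C/c1ccc(Br)cc1`) gives > 300 mg/kg and this too is only a limit. Compound 2 therefore has no number to its name, and no order can be read among the three.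

The next compound, compound 4 (`COc1cc(OC)c(OC)cc1/C=C/COC(=O)/C=C/c1ccc(Cl)cc1`), carries chloro in place of bromo on an aromatic carbon, para to a large group (chloro in place of bromo on an aromatic carbon), and is otherwise the same as compound 2. For the measured compounds named here, the only measured step on hand is a step that the two limits leave unreadable from compound 1 to compound 3 and it concerns hydrogen in place of methoxy on an aromatic carbon, a different exchange that offers no size to carry over. With nothing measured for the exchange of bromo for chloro, no step beyond the scatter is expected in this assay in either direction. The estimate leans on compound 2 at > 300 mg/kg and that value is a limit. The step expected is a number no higher from compound 2 to compound 4 (the limit leaves the size open) in this estimate. For compound 4 the estimated value is 300 mg/kg with an expected range from 130 mg/kg to 600 mg/kg and a report as a limit is likely.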

Compound 4, dose for half-maximal effect: > 200 mg/kg
Compound 4 ended at the assay's limit (the forecaster's own chance of this, stated with the estimate: 70%); the middle value lies beyond the limit too.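

In this assay compound 4 gives > 200 mg/kg, which is a limit and not a number. For the compounds shown here, compound 2 is also reported only as a limit, so no step between compound 2 and compound 4 can be read. The compounds shown leave open how chloro and bromo compare, and whether any of these esters has a measurable half-maximal dose.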